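The source may report more compounds than this note shows. Statements on the series, on what has been measured and on what is new or still open speak of the compounds shown alone.

In a functional assay on Fem-X cells (Homo sapiens) for cytotoxicity, read by MTT assay, with a stated time of 72 h (on this read-out lower numbers stand for stronger inhibition and higher numbers for weaker inhibition), compound 1 `CC(C)(C)C1=CC(=O)C=C(NCC(=O)O)C1=O` gives 34300 nM, and it stands among close neighbours. Removing its (carboxymethyl)amino group leads to compound 2 `CC(C)(C)C1=CC(=O)C=CC1=O`, which gives 41600 nM, a 1.2-fold higher number from compound 1 to compound 2 (0.08 log units; within the scatter). Compound 3 `CC(C)[C@@H](NC1=CC(=O)C=C(C(C)(C)C)C1=O)C(=O)O`, with isopropyl on the saturated chain carbon bound to an amine nitrogen and a carbonyl carbon, gives 24600 nM, a 1.4-fold lower number from compound 1 to compound 3 (0.14 log units; within the scatter). Compound 4 `CC(C)C[C@H](NC1=CC(=O)C=C(C(C)(C)C)C1=O)C(=O)O` has isobutyl in place of hydrogen at that same place (isobutyl in place of hydrogen on a saturated chain carbon bound to an amine nitrogen and a carbonyl carbon). Compound 3 is the nearest guide, and its step stayed within the scatter, so no step beyond the scatter is expected in this assay. The estimated change is a 1.4-fold lower number from compound 1 to compound 4 (0.16 log units; within the scatter). For compound 4 the expected value is 24000 nM, within an estimated range of 12000 nM to 48000 nM.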

Compound 4, half-maximal inhibitory concentration: 39400 nM
Compound 4: middle estimate off by 1.6-fold (0.22 log units), on the low side, within the range that was stated.
By their numbers in this assay, from the lowest: compounds 3, 1, 4 and 2 (each within the scatter of the next).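

At this carbon, isobutyl in place of hydrogen gives a 1.1-fold higher number from compound 1 to compound 4 (0.06 log units; within the scatter) in this assay, so a second, larger chain also leaves the number within the scatter of compound 1. Together with compound 3, this shows that neither of these two carbon chains at this place separates from the hydrogen of compound 1. No evidence here offers an explanation for this result. Still open, on these data alone, is whether a benzyl group, or a chain ending in an amine or a carboxylic acid, would produce a step beyond the scatter at this place.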